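The source may report more compounds than this note shows. Statements on the series, on what has been measured and on what is new or still open speak of the compounds shown alone.

Series notes, activity at a single concentration.

In a functional assay on COLO 205 cells (Homo sapiens) for cytotoxicity, read by sulforhodamine B assay, with a stated time of 48 h, tested at 0.01 uM (a lower number here means a stronger effect, a higher number a weaker effect of the compound at the concentration tested), compound 1 `COc1cc(-c2cc(/C=C/C(=O)c3ccc(N)cc3)[nH]n2)cc(OC)c1OC` gives 93%, the second highest of three numbers. Its nearest neighbour is compound 2 `COc1ccc(-c2cc(/C=C/C(=O)c3ccc(N)cc3)[nH]n2)cc1OC`, which in this assay gives 92%; the furthest is compound 3 `COc1ccc(-c2cc(/C=C/C(=O)c3cc(OC)c(OC)c(OC)c3)[nH]n2)cc1OC`, which in this assay gives 99%. Both gaps to compound 1 lie within the scatter, so the three measured compounds cannot be ordered on these numbers.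

Within the data shown here, the one measured step, a number 1 percentage points lower from compound 1 to compound 2 (within the scatter), changes the ring attached to the shared core and not the ring on the carbonyl carbon, so it has no direct bearing on the change to compound 4 `COc1cc(-c2cc(/C=C/C(=O)c3ccc(F)c(F)c3)[nH]n2)cc(OC)c1OC`. That change is 3,4-difluorophenyl in place of 4-aminophenyl on a carbonyl carbon. Compounds 2 and 3 differ on the carbonyl-side ring, but their two values in this assay sit within the scatter of each other, which is all that pair shows.

Among the measured compounds shown here, no measured step therefore speaks to the exchange at the carbonyl carbon, and no step beyond the scatter is expected in this assay. Compound 4 is estimated at 92%, with a range from 78% to 102%, an expected step of a number 1 percentage points lower from compound 1 to compound 4 (within the scatter).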

Compound 4, a percentage reported as activity, at one concentration (the size of the read-out at that concentration, not a potency): 101%
For compound 4 the middle estimate is 9 percentage points below the measured one, within the range that was stated.
By their numbers in this assay, from the lowest: compounds 2, 1, 3 and 4 (each within the scatter of the next).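

In this assay, among these compounds, the exchange of 4-aminophenyl for 3,4-difluorophenyl on a carbonyl carbon gives a number 8 percentage points higher from compound 1 to compound 4 (within the scatter) and is the first direct reading at this position with the rest of compound 1 held fixed. The entering group has no hydrogen-bond donor or acceptor, whereas the leaving group has one of each, yet the read-out at this single concentration stays inside the scatter. No measurement at hand bears on the reason for this result.

As far as these compounds go, whether any other group on the carbonyl carbon, such as a carboxylic acid or a morpholine, would move the read-out beyond the scatter stays open. From the compounds shown here alone, it is also open whether compound 1 and compound 4 would remain within the scatter of each other at a higher concentration.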